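The compounds below may be only part of what the source reports. "The series", "measured", "known", "first", "only" and "open" are said of these compounds alone.

In an ADME assay on L132 cells (Homo sapiens) for cytotoxicity, read by MTT assay, with a stated time of 72 h (a lower number here means a stronger inhibitor, a higher number a weaker inhibitor), compound 1 `COc1ccc(C2=C(c3cc(OC)c(OC)c(OC)c3)C(=O)CC2O[SiH2]C(C)(C)C)cc1OC` gives > 100 ug/mL, a limit and not a number. Compound 2 `COc1cc(C2=C(c3ccccc3)C(O[SiH2]C(C)(C)C)CC2=O)cc(OC)c1OC` gives > 100 ug/mL, likewise a limit. Going by the values given here, the series so far stands wholly at the limit of > 100 ug/mL in this assay, at which 2 of the 2 values shown sit. Among the compounds with values here, the one measured step, a step that the two limits leave unreadable from compound 1 to compound 2, changes a group on a double-bonded ring carbon, as does the move to compound 3 `COc1cc(C2=C(c3cc(C)c(OC)c(C)c3)C(O[SiH2]C(C)(C)C)CC2=O)cc(OC)c1OC`: 4-methoxy-3,5-dimethylphenyl in place of phenyl on a double-bonded ring carbon. That step offers no size to carry over. No step beyond the scatter is expected in this assay, and the estimated step is a number no higher from compound 2 to compound 3 (the limit leaves the size open). For compound 3 the estimate is 100 ug/mL, with an expected range from 40 ug/mL to 250 ug/mL.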

Compound 3, half-maximal inhibitory concentration: > 100 ug/mL
Compound 3: only a limit was reported (the forecaster's own chance of this, stated with the estimate: 70%); the middle value lies on the limit itself.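

The steps among compound 1, compound 2 and compound 3 cannot be read, each value being a limit. Left open is whether any group on the double-bonded ring carbon moves the series in this assay from where it stands: the limit of > 100 ug/mL in this assay, at which 3 of the 3 values shown sit.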